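Lengthening the ester chain in glycolamide vanilloids

The source may hold more compounds than are shown below. What is called first, only, known or untested is meant among the compounds shown, and "the series" means these compounds.

Compound 1 `CCCCCCCC(=O)OCC(=O)NCc1ccc(O)c(OC)c1`: 40 nM
Compound 2 `CCCCCCCCCC(=O)OCC(=O)NCc1ccc(O)c(OC)c1`: 200 nM
Compound 3 `CCCCCCCCCCCCCCC(=O)OCC(=O)NCc1ccc(O)c(OC)c1`: 330 nM

All three compounds share one core and differ only in the length of the saturated chain of the ester. In an assay on SH-SY5Y cells for agonist activity at transient receptor potential cation channel subfamily V member 1 (Homo sapiens), read by fluorescence and calcium flux, with a stated time of 25 min (a lower number here means that less compound is needed, a higher number that more compound is needed for the effect), compound 3 gives 330 nM, the highest number of the three. Its nearest neighbour is compound 2, for which the difference a 1.7-fold higher number from compound 2 to compound 3 (0.22 log units; within the scatter) lies within the scatter, whereas against compound 1 the difference an 8.3-fold higher number from compound 1 to compound 3 (0.92 log units; beyond the scatter) is clear. The shorter step a 5.0-fold higher number from compound 1 to compound 2 (0.70 log units; beyond the scatter) points the same way.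

Compound 4 `CCCCCCCC/C=C\CCCCCCCC(=O)OCC(=O)NCc1ccc(O)c(OC)c1` carries a longer, unsaturated chain: dec-1-en-1-yl in place of heptyl on a saturated chain carbon, seven bonds along the chain from a carbonyl carbon. Within the data shown here, the steps so far show the number rising as the chain grows from compound 1 to compound 2 and to compound 3, with the last extension, from compound 2 to compound 3, already too small to stand out. Among the measured compounds shown here, no measured step tells what the double bond adds. Extending further is therefore expected to raise the number only a little, or not beyond the scatter: the estimated step is a 1.5-fold higher number from compound 3 to compound 4 (0.18 log units; within the scatter). For compound 4 the expected value in this assay is 500 nM, with a range from 200 nM to 1300 nM.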

Compound 4, half-maximal effective concentration: 320 nM
Estimate against measurement, compound 4: 1.6-fold (0.19 log units) above, and the stated range covers the measured number.
By their numbers in this assay, from the lowest: compound 1; then compounds 2, 4 and 3 (each within the scatter of the next).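

In this assay, the longer dec-1-en-1-yl chain with its double bond and the heptyl chain, at this place seven bonds along from a carbonyl carbon, cannot be told apart (compare a 1.0-fold lower number from compound 3 to compound 4 (0.01 log units; within the scatter)). Compound 4 also stays within the scatter of the ethyl-extended chain (a 1.6-fold higher number from compound 2 to compound 4 (0.20 log units; within the scatter)), while the gap to the shortest chain is clear (an 8.0-fold higher number from compound 1 to compound 4 (0.90 log units; beyond the scatter)), so only compound 1 stands apart from the other three. No measurement here gives a reason for this result.

The effect of the double bond remains separate and unknown, since a fully saturated chain of the same length as in compound 4 is not among these compounds. Chains shorter than that of compound 1, and an amide in place of the ester, also remain open.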